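Trimming the oxadiazole phenyl of compound 3 to methyl

A few compounds are considered here, and "the series" means these few. Any claim that something is new, unique, unknown or untested is made for them only; others in the source may bear on it.

In a functional assay on HUVEC cells (Homo sapiens) for inhibition, read by ELISA (a higher number here means a weaker inhibitor, a lower number a stronger inhibitor), compound 3 `COc1c(C)cnc(C[S+]([O-])c2nnc(-c3ccccc3)o2)c1C` gives 6000 nM, the second highest of the three numbers measured. Its closest neighbour is compound 2 `CCCc1nnc([S+]([O-])Cc2ncc(C)c(OC)c2C)o1`, which in this assay gives 8000 nM; the step of a 1.3-fold lower number from compound 2 to compound 3 (0.12 log units; within the scatter) is the only one in which a single change separates two measured compounds, and it stays within the scatter. Compound 1 `[O-][S+](Cc1ccccc1)c1nnc(-c2ccncc2)o1` gives 3000 nM in this assay, and its value and that of compound 3 lie within the scatter of each other.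

Compound 4 `COc1c(C)cnc(C[S+]([O-])c2nnc(C)o2)c1C` has not been measured. It differs from compound 3 as follows: methyl in place of phenyl on an aromatic carbon. For the measured compounds named here, no measured pair swaps phenyl for methyl at this place, so the only relevant step is the propyl-to-phenyl step from compound 2 to compound 3, which was small. On that basis compound 4 is expected to show a step of a 1.3-fold higher number from compound 3 to compound 4 (0.12 log units; within the scatter), not beyond the scatter. Compound 4 is therefore estimated at 8000 nM in this assay, with a range from 3000 nM to 20000 nM.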

Compound 4, half-maximal inhibitory concentration: 8000 nM
Beside the measured number, compound 4's estimate shows no gap at the digits printed, within the range that was stated.
By their numbers in this assay, from the lowest: compounds 1, 3, 2 and 4 (each within the scatter of the next, the first and the last beyond it).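

Exchanging the phenyl, with its six-membered aromatic ring, for methyl on this aromatic carbon of the five-membered ring gives in this assay a step that stays within the scatter: a 1.3-fold higher number from compound 3 to compound 4 (0.12 log units; within the scatter). The change from the propyl of compound 2 to methyl, read as hydrogen in place of ethyl on a saturated chain carbon, gives no change at the digits printed from compound 2 to compound 4 (within the scatter), so that methyl, propyl and phenyl at this position, on the shared core of compounds 2, 3 and 4, all lie within the scatter of one another. No evidence is available that bears on this result. The compounds shown carry no amine, carboxylic acid or longer chain at this carbon. Going by these compounds, whether any such group would give a step beyond the scatter therefore remains open.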